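This account rests on a few compounds, and the source may have more. Where it says the series, first, only, none or still open, it means among the compounds named here.

Measured so far in a physicochemical assay for solubility, at pH 7.4; on this read-out higher numbers stand for higher solubility and lower numbers for lower solubility:

- Compound 1 `Cn1nc(C(=O)Nc2ccc(-c3ccccc3)c(C(F)(F)F)c2)c(=O)c2ccccc21`: < 1 ug/mL (a limit of the assay, not a number)
- Compound 2 `Cn1cc(C(=O)Nc2ccc(-c3ccccc3)c(C(F)(F)F)c2)c(=O)c2ccccc21`: 1.3 ug/mL

Going by the values given here, compound 2 gives 1.3 ug/mL, the only true number in this small set. The entry for compound 1 is a limit of the assay rather than a number: the limit of < 1 ug/mL in this assay, at which 1 of the 2 values shown sits. Compound 2 is therefore the only firm starting point for what follows.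

The next compound changes one place in compound 2. Compound 3 `Cn1cc(C(=O)Nc2ccc(-c3cccnc3)c(C(F)(F)F)c2)c(=O)c2ccccc21` carries pyridin-3-yl in place of phenyl on an aromatic carbon, ortho to a trifluoromethyl group. The count of that swap is pyridin-3-yl in place of phenyl on an aromatic carbon.

Among the compounds with values here, no measured pair in this set shows what such a swap does, so the expectation rests on the structural change alone. A modest upward move in this assay is expected, and the true result could still fall within the usual scatter. The estimated size of that move is a 3.1-fold higher number from compound 2 to compound 3 (0.49 log units; beyond the scatter). For compound 3 the estimate is 4 ug/mL, with an expected range from 1.5 ug/mL to 15 ug/mL.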

Compound 3, solubility: 23 ug/mL
Estimate against measurement, compound 3: 5.8-fold (0.76 log units) below; measured number outside the range, above it.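

On the ring that carries the change, the position ortho to a trifluoromethyl group and para to a large group turns out to matter for this read-out. In this assay, pyridin-3-yl in place of phenyl gives an 18-fold higher number from compound 2 to compound 3 (1.25 log units; beyond the scatter), a large step and well beyond the usual scatter of the measurement. The heavy atom count at this place stays the same, so the two compounds differ by a single ring nitrogen in place of a ring carbon, along with the one hydrogen-bond acceptor that enters with it, and even that small edit is enough to lift the number far from where compound 2 sits.

No measurement shown here bears on why the number moves this far. Still open, going by these compounds, is whether a pyridin-4-yl ring, or a phenyl ring carrying an amine or a carboxylic acid, would do the same at this position, and whether pyridin-3-yl would bring a similar gain on the core of compound 1.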